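Hydroxy for ethyl at the ring carbon of the series

The compounds below may be only part of what the source reports. "The series", "measured", "known", "first", "only" and "open" are said of these compounds alone.

Two members of the series have been measured in an assay on cells for inhibition of sodium/hydrogen exchanger (Oryctolagus cuniculus); on this read-out higher numbers stand for weaker inhibition and lower numbers for stronger inhibition. Compound 1 `Cc1cc2c(cc1C(=O)N=C(N)N)S(=O)(=O)CC2C(C)C` gives 21 nM in this assay, and compound 2 `CCC1CS(=O)(=O)c2cc(C(=O)N=C(N)N)c(C)cc21` gives 24 nM in this assay; the two numbers lie within the scatter of each other, so neither compound can be set apart from the other on this read-out. Among the compounds with values here, the only measured step, a 1.1-fold higher number from compound 1 to compound 2 (0.06 log units; within the scatter), removes a methyl from the branch and leaves the number essentially unchanged.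

Compound 3 `Cc1cc2c(cc1C(=O)N=C(N)N)S(=O)(=O)CC2O` has not been measured in this assay. It differs from compound 2 by hydroxy in place of ethyl on a saturated ring carbon. Within the data shown here, no measured step exchanges an alkyl group for a group carrying a hydrogen-bond donor and acceptor at this ring carbon, and the one step available, a 1.1-fold higher number from compound 1 to compound 2 (0.06 log units; within the scatter), only shortens the chain. The expectation for compound 3 therefore rests on weak ground. A loss of the whole chain is expected to matter more than the loss of one methyl, so compound 3 is expected to show a number of 70 nM in this assay, between 20 nM and 250 nM. That estimate means a 2.9-fold higher number from compound 2 to compound 3 (0.46 log units; beyond the scatter), a step expected to go beyond the scatter toward weaker inhibition.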

Compound 3, half-maximal inhibitory concentration: 70 nM
Compound 3: middle estimate and measured number agree at the digits printed; low and high end bracket the measured number.
By their numbers in this assay, from the lowest: compounds 1 and 2 (each within the scatter of the next); then compound 3.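

Within the data shown here, at this saturated ring carbon, two ring bonds from the ring sulfur, replacing an alkyl group with hydroxy is the first change to move the number beyond the scatter in this assay: hydroxy in place of ethyl gives a 2.9-fold higher number from compound 2 to compound 3 (0.46 log units; beyond the scatter), and hydroxy in place of isopropyl gives a 3.3-fold higher number from compound 1 to compound 3 (0.52 log units; beyond the scatter). The position is therefore not indifferent to what it carries, as the isopropyl and ethyl pair alone might have suggested, yet both steps are modest and compound 3 still gives 70 nM, so inhibition is weakened rather than lost with hydroxy at this carbon. No supporting data bear on why the number shifts.

The steps leave open whether the shift follows from the loss of the alkyl chain or from the entering hydroxy, as the change swaps ethyl, with no hydrogen-bond donor or acceptor, for hydroxy, with one of each. A methoxy group, an amine or a bare hydrogen at this ring carbon would help separate these two readings, and a longer chain such as n-butyl would show how far the alkyl side of the series extends.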